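This account rests on a few compounds, and the source may have more. Where it says the series, first, only, none or still open, it means among the compounds named here.

Compound 1 `COc1ccc(Cc2nnc(CN(c3cccc(Cl)c3C)S(=O)(=O)c3ccc(C)cc3)o2)cc1`: 6.31 nM in an assay on CHO cells for displacement of a labelled ligand from prostaglandin E2 receptor EP1 subtype (Homo sapiens); on this read-out lower numbers stand for stronger inhibition and higher numbers for weaker inhibition
Compound 2 `CCOc1ccc(Cc2nnc(CN(c3cccc(Cl)c3C)S(=O)(=O)c3ccc(C)cc3)o2)cc1`: 3.98 nM
Compound 3 `CCOc1ccc(Cc2nnc(CN(c3cccc(Cl)c3Cl)S(=O)(=O)c3ccc(C)cc3)o2)cc1`: 6.31 nM

Three compounds share one core and differ only in small groups at its edges. For the measured compounds named here, compound 2 gives the lowest of the three numbers, but its neighbours sit close: the step of a 1.6-fold lower number from compound 1 to compound 2 (0.20 log units; within the scatter) and the step of a 1.6-fold higher number from compound 2 to compound 3 (0.20 log units; within the scatter) both stay within the scatter, so no compound can be called the strongest.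

Compound 4 `Cc1ccc(S(=O)(=O)N(Cc2nnc(Cc3ccc(N(C)C)cc3)o2)c2cccc(Cl)c2C)cc1` has not yet been measured. It differs from compound 2 in one place: dimethylamino in place of ethoxy on an aromatic carbon. Neither measured step covers this exact exchange. The nearer one is a 1.6-fold lower number from compound 1 to compound 2 (0.20 log units; within the scatter), which altered the same ethoxy group and changed little; the other, a 1.6-fold higher number from compound 2 to compound 3 (0.20 log units; within the scatter), touched a different ring and also changed little. With only small movements seen so far, the expected step of a 1.3-fold higher number from compound 2 to compound 4 (0.10 log units; within the scatter) is none beyond the scatter. Compound 4 is therefore estimated at 5 nM, with a range from 2 nM to 16 nM.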

Compound 4, half-maximal inhibitory concentration: 12.6 nM
Compound 4: middle estimate off by 2.5-fold (0.40 log units), on the low side; measured number inside the range.
By their numbers in this assay, from the lowest: compounds 2, 1, 3 and 4 (each within the scatter of the next, the first and the last beyond it).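

Placing dimethylamino on the aromatic ring, para to a large group, gives a 3.2-fold higher number from compound 2 to compound 4 (0.50 log units; beyond the scatter), the only step in this set that lies beyond the scatter, so this position does respond to the group it carries, even though ethoxy and dimethylamino match in heavy atoms and hydrogen-bond acceptors. The effect is modest and depends on the comparison: measured against the methoxy group, the exchange gives a 2.0-fold higher number from compound 1 to compound 4 (0.30 log units; within the scatter), which stays within the scatter. Nothing measured here accounts for the difference between the ethoxy and dimethylamino groups.

The compounds shown leave open whether the weaker binding in this assay belongs to dimethylamino alone or extends to other groups at this place, such as a primary amine, a carboxylic acid or a longer chain like butoxy. They also leave open how dimethylamino behaves when chloro replaces methyl on the other ring.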